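Swapping Bromine for Iodine on a Pyridine-Bearing Oxadiazole Ketone

A few compounds are considered here, and "the series" means these few. Any claim that something is new, unique, unknown or untested is made for them only; others in the source may bear on it.

Measured so far:
Compound 1, `O=C(CCCCCc1ccccc1)c1nc2cccc(F)c2o1`, gives > 10000 nM in an assay on HEK-293T cells for inhibition of diacylglycerol lipase-alpha (Homo sapiens), read by colorimetric assay; on this read-out lower numbers stand for stronger inhibition and higher numbers for weaker inhibition.
Compound 2, `O=C(CCCCCCc1ccccc1)c1ncno1`, gives > 10000 nM.
Compound 3, `O=C(CCCCCCc1ccccc1)c1nc(-c2cccc(Br)n2)no1`, gives 2040 nM.

The values of compound 1 and compound 2 are limits of the assay rather than numbers. Among the measured compounds shown here, compound 3 is thus the only compound with a measured number; the other two values sit at a limit, as noted in the limit of > 10000 nM in this assay, at which 2 of the 3 values shown sit. For the measured compounds named here, the one measured step, an at least 4.9-fold lower number from compound 2 to compound 3 (0.69 log units; beyond the scatter), is the addition of a whole substituted ring to a bare aromatic carbon.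

Compound 4, `O=C(CCCCCCc1ccccc1)c1nc(-c2cccc(I)n2)no1`, is not yet measured. It differs from compound 3 by iodo in place of bromo on an aromatic carbon, on an aromatic carbon of a six-membered aromatic ring with one nitrogen, next to the ring nitrogen. Going by the values given here, no measured step involves a change of one halogen for another, so the step from compound 2 to compound 3 does not bear on it directly. A step of no more than the usual scatter is therefore expected: a 1.0-fold lower number from compound 3 to compound 4 (0.01 log units; within the scatter). Compound 4 is estimated at 2000 nM, between 800 nM and 5000 nM.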

Compound 4, half-maximal inhibitory concentration: > 10000 nM
Compound 4 was reported as a limit (the forecaster's own chance of this, stated with the estimate: 10%); middle value at least 5.0-fold (0.69 log units) away from the limit.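

Changing bromo to iodo, one heavy atom for one on an aromatic carbon next to the ring nitrogen, gives an at least 4.9-fold higher number from compound 3 to compound 4 (0.69 log units; beyond the scatter), and a higher number here means weaker inhibition. The halogen at this position therefore matters: the gain seen on adding the 6-bromopyridin-2-yl group, an at least 4.9-fold lower number from compound 2 to compound 3 (0.69 log units; beyond the scatter), cannot be assumed for the same ring with another halogen. As far as these compounds go, the value of compound 4 is a limit and not a number, so the full size of this step stays unknown, and the step from compound 2 to compound 4 cannot be read: the limit of > 10000 nM in this assay, at which 3 of the 4 values shown sit.

From the compounds shown here alone, whether chloro, fluoro or an amine at this position would match or improve on compound 3 remains open. So does whether a longer chain would alter the effect of the halogen on the iodo or bromo compound.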